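The source may hold more compounds than are shown below. What is called first, only, known or untested is meant among the compounds shown, and "the series" means these compounds.

Compound 1 `O=S(=O)(Nc1ccc(-c2nc3ccccc3o2)cc1)c1cccc(Cl)c1` gives 54000 nM in an assay on cells for inhibition of HSP60/HSP10 (Homo sapiens), with a stated time of 60 min; a lower number here means a stronger inhibitor, a higher number a weaker inhibitor. Compound 2 `O=S(=O)(Nc1ccc(-c2nc3ccccc3o2)cc1)c1ccccc1O` reaches only the limit of the assay there, > 100000 nM. Compound 3 `Cc1cccc(S(=O)(=O)Nc2ccc(-c3nc4ccccc4o3)cc2)c1` likewise sits at the assay limit, > 100000 nM, so it stands among the weakest numbers shown, sharing the limit with compound 2 (the limit of > 100000 nM in this assay, at which 2 of the 3 values shown sit). Compound 4 `O=S(=O)(Nc1ccc(-c2nc3ccccc3o2)cc1)c1cccc(O)c1` differs from compound 3 by hydroxy in place of methyl on an aromatic carbon. Going by the values given here, no measured step swaps hydroxy for methyl on that carbon; the nearest are an at least 1.8-fold higher number from compound 1 to compound 3 (0.26 log units; that floor lies within the scatter) and an at least 1.8-fold higher number from compound 1 to compound 2 (0.26 log units; that floor lies within the scatter), both small and both pointing toward weaker inhibition, while a step that the two limits leave unreadable from compound 2 to compound 3. Compound 4 is therefore expected to stay near the limit, a step of a number no higher from compound 3 to compound 4 (the limit leaves the size open). Compound 4 is estimated at 100000 nM, within 40000 nM to 200000 nM.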

Compound 4, half-maximal inhibitory concentration: 62000 nM
The estimate for compound 4 lay 1.6-fold (0.21 log units) above the measured number, and the stated range covers the measured number.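

In this assay, hydroxy on this carbon gives a readable number where methyl leaves only a limit, though the readable floor of the step is small: an at least 1.6-fold lower number from compound 3 to compound 4 (0.20 log units; that floor lies within the scatter). The 3-hydroxyphenyl likewise gives a number where the 2-hydroxyphenyl does not, with an at least 1.6-fold lower number from compound 2 to compound 4 (0.20 log units; that floor lies within the scatter), and against chloro on the same carbon the result is a 1.1-fold higher number from compound 1 to compound 4 (0.06 log units; within the scatter), so hydroxy and chloro cannot be told apart here. Compound 2 and compound 3 stay at a limit: the limit of > 100000 nM in this assay, at which 2 of the 4 values shown sit.

As far as these compounds go, whether an amine or a carboxylic acid on this carbon would move the number beyond the scatter stays open. From the compounds shown here alone, how far compound 2 and compound 3 truly lie from compound 4 also stays open.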